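Series notes: carbamoyl to benzoyl on the shared core

The source may hold more compounds than are shown below. What is called first, only, known or untested is meant among the compounds shown, and "the series" means these compounds.

Measured so far:
compound 1 `N#C/C(=C\N1CCN(C(=O)c2ccco2)C1=S)C(=O)Nc1ccc(Cl)cc1`: 21000 nM
compound 2 `N#C/C(=C\N1CCN(C(=O)c2ccco2)C1=S)C(N)=O`: 1700 nM

For the measured compounds named here, in a functional assay on MCF7 cells (Homo sapiens) for inhibition, read by sulforhodamine B assay, with a stated time of 48 h (on this read-out higher numbers stand for weaker inhibition of growth and lower numbers for stronger inhibition of growth), compound 2 gives 1700 nM, the lower of the two numbers; its only neighbour is compound 1, which gives 21000 nM. Going by the values given here, the step of a 12-fold lower number from compound 1 to compound 2 (1.09 log units; beyond the scatter) is the sole measured comparison in the set.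

Compound 3 `N#C/C(=C\N1CCN(C(=O)c2ccco2)C1=S)C(=O)c1ccccc1` is unmeasured. It differs from compound 2 by phenyl in place of amino on a carbonyl carbon. The measured step bears on it only indirectly: a 12-fold lower number from compound 1 to compound 2 (1.09 log units; beyond the scatter) shows that taking an aryl group off the amide-type nitrogen lowered the number, and compound 3 brings an aryl group back, this time on the carbonyl carbon. A partial reversal of that gain is therefore expected in this assay, a rise in the number short of a full return to the level of compound 1. The step of a 3.5-fold higher number from compound 2 to compound 3 (0.55 log units; beyond the scatter) is expected. Compound 3 is estimated at 6000 nM, with a range of 1500 nM to 25000 nM.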

Compound 3, concentration for 50% growth inhibition: 4500 nM
Estimate against measurement, compound 3: 1.3-fold (0.12 log units) above, and the stated range covers the measured number.
By their numbers in this assay, from the lowest: compound 2; then compound 3; then compound 1.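

In this assay, the change from carbamoyl to benzoyl gives a 2.6-fold higher number from compound 2 to compound 3 (0.42 log units; beyond the scatter), so an aromatic ring placed directly on the carbonyl carbon still costs something against the plain amino group, though the cost is modest. Phenyl in place of (4-chlorophenyl)amino on the same carbon gives a 4.7-fold lower number from compound 1 to compound 3 (0.67 log units; beyond the scatter), which shows that an aryl-bearing group at this position does not by itself return the number to the level of compound 1; among the three compounds, the order runs with the amino group of compound 2 lowest and the (4-chlorophenyl)amino group of compound 1 highest. No measurement on hand accounts for either step.

Still open, on these data alone, is how much of the gap from compound 1 to compound 3 belongs to the chlorine and how much to the amide nitrogen, which an unsubstituted phenylamino group on the carbonyl carbon would help separate. A small methyl or a methylamino group at this carbon would show whether the rise tracks the aromatic ring or the loss of the amino group.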